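Chloro for trifluoromethyl in a pair of weak aryl ureas

The source may report more compounds than this note shows. Statements on the series, on what has been measured and on what is new or still open speak of the compounds shown alone.

Measured so far, in a functional assay on SF-295 cells (Homo sapiens) for inhibition, read by sulforhodamine B assay, with a stated time of 48 h, tested at 0.1 uM; a higher number here means a weaker effect of the compound at the concentration tested, a lower number a stronger effect:
compound 1 `O=C(Nc1cccc(-n2cc(-c3ccncc3)c(-c3cc(O)cc(Cl)c3)n2)c1)Nc1ccc(Cl)c(Cl)c1` gives 87%
compound 2 `COc1cc(Cl)cc(-c2nn(-c3cccc(NC(=O)Nc4ccc(Cl)c(C(F)(F)F)c4)c3)cc2-c2ccncc2)c1` gives 98%

Compound 2 stands highest of these two numbers; compound 1, the nearest, lies lower by a gap beyond the usual scatter. Compound 3 `COc1cc(Cl)cc(-c2nn(-c3cccc(NC(=O)Nc4ccc(Cl)c(Cl)c4)c3)cc2-c2ccncc2)c1` differs from compound 2 by chloro in place of trifluoromethyl on an aromatic carbon. Within the data shown here, no step between two measured compounds is known to guide this change, so the step from compound 2 to compound 3 in this assay is expected to be small, downward, and the expected change is a number 6 percentage points lower from compound 2 to compound 3 (within the scatter). Compound 3 is estimated at 92%, within a range from 80% to 102%.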

Compound 3, a percentage reported as activity, at one concentration (the size of the read-out at that concentration, not a potency): 57%
For compound 3 the middle estimate is 35 percentage points above the measured one; measured number outside the range, below it.
By their numbers in this assay, from the lowest: compound 3; then compound 1; then compound 2.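

In this assay the trifluoromethyl position proves sensitive: chloro in its place gives a stronger effect, with a step of a number 41 percentage points lower from compound 2 to compound 3 (beyond the scatter) at the concentration tested. With the 3,4-dichlorophenyl group held constant, methyl in place of hydrogen on the oxygen also strengthens the effect, with a step of a number 30 percentage points lower from compound 1 to compound 3 (beyond the scatter) and so the two changes each count on their own. No evidence on hand accounts for either step.
As far as these compounds go, whether bromo or methyl on that aromatic carbon would match chloro remains open. So does whether an ethyl chain or a carboxylic acid on the oxygen would keep the gain.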